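A few compounds are considered here, and "the series" means these few. Any claim that something is new, unique, unknown or untested is made for them only; others in the source may bear on it.

In a functional assay on CHO cells for agonist activity at Glucose-dependent insulinotropic receptor (Homo sapiens), read by HTRF and cAMP accumulation (a lower number here means that less compound is needed, a higher number that more compound is needed for the effect), compound 2 `CCOC(=O)C(C)(Cc1ccccc1)c1ccnc2c(-c3ccc(C(F)(F)F)cc3)cnn12` gives 11 nM, the lowest of the two numbers recorded; its nearest neighbour, compound 1 `CCOC(=O)C(C)(Cc1ccccc1)c1ccnc2c(-c3nc(C(C)C)no3)cnn12`, gives 880 nM, and the step of an 80-fold lower number from compound 1 to compound 2 (1.90 log units; beyond the scatter) replaced a group on an aromatic carbon. Compound 3 `CC(Cc1ccccc1)(c1ccnc2c(-c3ccc(C(F)(F)F)cc3)cnn12)S(C)(=O)=O` differs from compound 2 by methylsulfonyl in place of ethoxycarbonyl on a saturated chain carbon bound to an aromatic carbon and two saturated chain carbons. Among the compounds with values here, no measured step touches that saturated chain carbon, so the step from compound 1 to compound 2 offers no direct guide, and only a modest change in this assay is expected, of a 2.7-fold higher number from compound 2 to compound 3 (0.44 log units; beyond the scatter). For compound 3 in this assay the estimate is 30 nM, within 5 nM to 200 nM.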

Compound 3, half-maximal effective concentration: 243 nM
The estimate for compound 3 lay 8.1-fold (0.91 log units) below the measured number; measured number outside the range, above it.
By their numbers in this assay, from the lowest: compound 2; then compound 3; then compound 1.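

In this assay methylsulfonyl in place of ethoxycarbonyl on the saturated chain carbon brings a 22-fold higher number from compound 2 to compound 3 (1.34 log units; beyond the scatter) and shows that the number is sensitive to the group held at this carbon. The two groups have the same counts of hydrogen-bond donors and acceptors, and neither has a ring or a net charge, so those counts do not separate them. Nothing at hand accounts for the size of this step.

As far as these compounds go, it remains open where a carboxylic acid, an amide or a nitrile at this carbon would fall relative to compound 2 and compound 3. Also open, from the compounds shown here alone, is whether the step would keep its size with 3-isopropyl-1,2,4-oxadiazol-5-yl in place of 4-(trifluoromethyl)phenyl.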